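The source may hold more compounds than are shown below. What is called first, only, known or untested is meant among the compounds shown, and "the series" means these compounds.

Working notes on the series.

Compound 1 `O=C(/C=C/c1cccc(Cl)c1Cl)Nc1cc2c(Nc3ccc(F)c(Cl)c3)ncnc2cc1O[C@H]1CCOC1` in a functional assay on PC-3 cells (Homo sapiens) for cytotoxicity, read by MTT assay, with a stated time of 72 h (a higher number here means a weaker inhibitor, a lower number a stronger inhibitor), gives 27500 nM. Within the data shown here, only one other compound in the set carries a number: compound 3 `O=C(/C=C/c1ccc(Br)cc1)Nc1cc2c(Nc3ccc(F)c(Cl)c3)ncnc2cc1O[C@H]1CCOC1` gives 28200 nM, and the step of a 1.0-fold higher number from compound 1 to compound 3 (0.01 log units; within the scatter) sits within the scatter, so the two stand together. Compound 2 `COc1cc(/C=C/C(=O)Nc2cc3c(Nc4ccc(F)c(Cl)c4)ncnc3cc2OC)cc(OC)c1` differs from compound 1 in more than one place; in this assay compound 2 is recorded as "not active" (no number reported), with no number behind it.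

The next compound, compound 4 `O=C(/C=C/c1cc(Br)c(O)c(Br)c1)Nc1cc2c(Nc3ccc(F)c(Cl)c3)ncnc2cc1O[C@H]1CCOC1`, differs from compound 1 in one place: 3,5-dibromo-4-hydroxyphenyl in place of 2,3-dichlorophenyl on a double-bonded chain carbon bound to a double-bonded chain carbon.

Among the measured compounds shown here, only the step from compound 1 to compound 3 bears on this change, since it also swaps the ring on the double-bonded chain carbon bound to a double-bonded chain carbon; that step was flat. For the measured compounds named here, compound 2 shows that a ring change made alongside another change can take the number out of range entirely, but no single-point step to it is available, so it gives no size.

The expectation for compound 4 is therefore a step of a 1.1-fold higher number from compound 1 to compound 4 (0.04 log units; within the scatter) that stays within the scatter, with some chance that this assay returns no number at all. Compound 4 is estimated at 30000 nM, within a range from 12000 nM to 80000 nM.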

Compound 4, half-maximal inhibitory concentration: 25500 nM
The estimate for compound 4 lay 1.2-fold (0.07 log units) above the measured number; measured number inside the range.
By their numbers in this assay, from the lowest: compounds 4, 1 and 3 (each within the scatter of the next).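

In this assay, the steps of a 1.1-fold lower number from compound 1 to compound 4 (0.03 log units; within the scatter) and a 1.1-fold lower number from compound 3 to compound 4 (0.04 log units; within the scatter) both lie within the scatter, so a third ring at this position, on a double-bonded chain carbon bound to a double-bonded chain carbon, leaves the number unmoved. Among these compounds, until now, the only readable comparison at this position was between 2,3-dichlorophenyl and 4-bromophenyl; the series now shows that 3,5-dibromo-4-hydroxyphenyl, with its hydrogen-bond donor and acceptor, also stands with them. Among the compounds shown here, the flat picture holds for compound 1, compound 3 and compound 4 only: compound 2 has no number and differs from compound 1 in more than one place, so no step to it can be read. No available evidence bears on this result.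

As far as these compounds go, whether the picture holds with an amine or a carboxylic acid on this ring, or with a longer chain in place of the ethenyl link, remains open. Also open, from the compounds shown here alone, is whether any group at this position can move the number beyond the scatter, since the three ring changes that can be compared here do not.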